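The source may hold more compounds than are shown below. What is called first, only, known or untested is meant among the compounds shown, and "the series" means these compounds.

In an ADME assay on S9 fraction from liver (Mus musculus, strain ICR/CD-1) for metabolic stability, read by LC-MS, using NADPH, with a stated time of 5 min, tested at 2 uM (on this read-out higher numbers stand for a longer-lived compound and lower numbers for a shorter-lived compound), compound 3 `CC1CCN(C2CCN(S(=O)(=O)c3cccc(-c4ccccc4F)c3)CC2)CC1` gives 0.283 h. Compound 2 `COc1ccccc1-c1cccc(S(=O)(=O)N2CCC(N3CCC(C)CC3)CC2)c1`, at 0.25 h, lies within the scatter of that number, while compound 1 `Cc1cc(Cl)cc(Cl)c1S(=O)(=O)N1CCC(N2CCC(C)CC2)CC1`, at 0.12 h, lies lower by more than the scatter. Compound 4 `CC1CCN(C2CCN(S(=O)(=O)c3cccc(-c4ccc(F)cc4)c3)CC2)CC1` differs from compound 3 by 4-fluorophenyl in place of 2-fluorophenyl on an aromatic carbon, meta to a large group. Within the data shown here, the only measured step at this group is a 1.1-fold higher number from compound 2 to compound 3 (0.05 log units; within the scatter). Among the measured compounds shown here, no measured pair shows the fluoro group moved, so that small step is the sole guide and no firm direction can be drawn from it. The expected change is a 1.1-fold lower number from compound 3 to compound 4 (0.04 log units; within the scatter), no larger than the scatter. For compound 4 the estimated half-life is 0.26 h, with an expected range of 0.13 h to 0.52 h.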

Compound 4, half-life: 1.28 h
Compound 4: middle estimate off by 4.9-fold (0.69 log units), on the low side, and the stated range ends below it.
By their numbers in this assay, from the lowest: compound 1; then compounds 2 and 3 (each within the scatter of the next); then compound 4.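

In this assay, exchanging 2-fluorophenyl for 4-fluorophenyl, with the same atoms joined differently, gives a 4.5-fold higher number from compound 3 to compound 4 (0.66 log units; beyond the scatter), whereas the earlier change of methoxy to fluoro gave only a 1.1-fold higher number from compound 2 to compound 3 (0.05 log units; within the scatter). The change from 2-methoxyphenyl to 4-fluorophenyl likewise gives a 5.1-fold higher number from compound 2 to compound 4 (0.71 log units; beyond the scatter), so at this position the place of the fluorine on the phenyl ring moves the half-life beyond the scatter. Nothing available explains this shift. As far as these compounds go, whether a chlorine or a nitrile in place of that fluorine would keep the longer half-life stays open.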